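From compound 2 to compound 3: adding a trifluoromethyl

The source may report more compounds than this note shows. Statements on the series, on what has been measured and on what is new or still open speak of the compounds shown alone.

Values in a functional assay on MCF7 cells (Homo sapiens) for antiproliferative activity, read by MTT assay, with a stated time of 72 h; on this read-out higher numbers stand for weaker inhibition and lower numbers for stronger inhibition:
- compound 1 `COc1ccc(C(=O)O[C@H]2CC[C@]3(C)[C@H](CC[C@@](C)(O)[C@H]3CC[C@@H]3C(C)=CC[C@H]4[C@H](CC[C@]4(C)O)C3(C)C)OC2(C)C)cc1`: 41700 nM
- compound 2 `CC1=CC[C@H]2[C@H](CC[C@]2(C)O)C(C)(C)[C@@H]1CC[C@H]1[C@]2(C)CC[C@H](OC(=O)c3ccccc3F)C(C)(C)O[C@H]2CC[C@@]1(C)O`: 11300 nM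

Of the two measured compounds, compound 2 holds the lower number, 11300 nM. Within the data shown here, the single measured step, a 3.7-fold lower number from compound 1 to compound 2 (0.57 log units; beyond the scatter), puts 2-fluorophenyl in place of 4-methoxyphenyl on a carbonyl carbon; it is modest but beyond the scatter.

Compound 3 `CC1=CC[C@H]2[C@H](CC[C@]2(C)O)C(C)(C)[C@@H]1CC[C@H]1[C@]2(C)CC[C@H](OC(=O)c3ccc(C(F)(F)F)cc3F)C(C)(C)O[C@H]2CC[C@@]1(C)O` keeps the shared core of compound 2 and differs from it thus: trifluoromethyl in place of hydrogen on an aromatic carbon. Trifluoromethyl stands in place of hydrogen on an aromatic carbon, meta to a fluoro group and para to a large group, giving 2-fluoro-4-(trifluoromethyl)phenyl.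

Among the measured compounds shown here, no measured step adds trifluoromethyl. For the measured compounds named here, the step of a 3.7-fold lower number from compound 1 to compound 2 (0.57 log units; beyond the scatter) is the only guide, since it changes the same aryl group, and it suggests a modest size but gives no direction for this change. A modest step of uncertain direction is therefore expected in this assay, with a slight lean toward a lower number. The estimated step is a 1.3-fold lower number from compound 2 to compound 3 (0.10 log units; within the scatter). Compound 3 is expected at 9000 nM, with an estimated range from 3500 nM to 22000 nM.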

Compound 3, half-maximal inhibitory concentration: > 50000 nM
Compound 3 ended at the assay's limit; the forecaster's own chance of this, stated with the estimate: 8%; middle value at least 5.5-fold (0.74 log units) from the limit.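

In this assay compound 3 gives > 50000 nM, which is a limit of the assay and not a number. The earlier step replaced one whole aryl group with another, whereas this one changes a single place, and adding trifluoromethyl para to a large group and meta to a fluoro group gives an at least 4.4-fold higher number from compound 2 to compound 3 (0.64 log units; beyond the scatter), so this aromatic carbon does not tolerate every change in this assay. The 2-fluorophenyl group's advantage over 4-methoxyphenyl also does not carry over to 2-fluoro-4-(trifluoromethyl)phenyl: the comparison reads an at least 1.1-fold higher number from compound 1 to compound 3 (0.07 log units; that floor lies within the scatter), and that floor lies within the scatter, so no order can be claimed for this pair.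

How far the true value of compound 3 lies past the limit cannot be read, and the size of the loss therefore stays open: the limit of > 50000 nM in this assay, at which 1 of the 3 values shown sits. Also open is whether the loss belongs to trifluoromethyl itself or would follow any substituent on this carbon, since a methyl, a chlorine or a methoxy group at the same place is not among the compounds shown.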